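Piperidinylmethyl for methylbenzyl in a cytotoxicity series

This account rests on a few compounds, and the source may have more. Where it says the series, first, only, none or still open, it means among the compounds named here.

Compound 1 `Cc1ccc(CN2CCC(C(=O)Nc3ccc(CNc4nc(N(C)C)nc5cc(C)ccc45)cc3)CC2)cc1` gives only a limit in a functional assay on SV5A8 cells (Homo sapiens) for cytotoxicity (on this read-out higher numbers stand for weaker inhibition and lower numbers for stronger inhibition), namely > 4150 nM. Compound 2 `Cc1ccc2c(NCc3ccc(NC(=O)C4CCN(Cc5ccccc5)CC4)cc3)nc(N3CCN[C@@H](C)C3)nc2c1` likewise reaches only the limit > 8860 nM. Compound 3 `CCNc1nc(NCc2ccc(NC(=O)C3CCN(Cc4ccccc4)CC3)cc2)c2ccc(C)cc2n1` stops at the limit > 2140 nM. Among the compounds with values here, the single one-point change within the measured set, a step that the two limits leave unreadable from compound 2 to compound 3, therefore stays unreadable. Compound 4 `Cc1ccc2c(NCc3ccc(NC(=O)C4CCN(CC5CCNCC5)CC4)cc3)nc(N(C)C)nc2c1` differs from compound 1 by piperidin-4-yl in place of 4-methylphenyl on a saturated chain carbon bound to an amine nitrogen in a ring. Within the data shown here, no measured step touches this position, and none of the three measured compounds yields a readable number, so no directional shift is expected from the change. The expected step that the limit leaves unreadable from compound 1 to compound 4 is nothing beyond the scatter. Compound 4 is estimated at 10000 nM, with a range from 3000 nM to 40000 nM, and is expected most likely to be reported again as a limit.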

Compound 4, half-maximal inhibitory concentration: > 8070 nM
Compound 4 gave a limit, no number; the forecaster's own chance of this, stated with the estimate: 80%; the middle value is on the limit's open side.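

Compound 1 and compound 4 both give only limits in this assay, so the step between them cannot be read. The compounds shown leave open whether swapping 4-methylphenyl for piperidin-4-yl shifts the value at all: none yields a number.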